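This account rests on a few compounds, and the source may have more. Where it says the series, first, only, none or still open, it means among the compounds named here.

Of the compounds shown here, three of one family have been measured in a functional assay on SH-SY5Y cells (Homo sapiens) for cytotoxicity, read by MTT assay, with stated times of 8 h, 30 min and 12 h, tested at 5 uM; a lower number here means a weaker effect, a higher number a stronger effect of the compound at the concentration tested. Compound 1 `N=C(NCc1ccc(O)cc1)[C@@H]1CCC(=O)N1Cc1ccccc1[N+](=O)[O-]` gives 30.4%. Compound 2 `COc1ccc(CNC(=N)[C@@H]2CCC(=O)N2Cc2ccccc2[N+](=O)[O-])cc1` gives 25.4%, and compound 3 `COc1ccc(CN2C(=O)CC[C@H]2C(=N)NCc2ccc(O)cc2)cc1` gives 26.6%. The change from compound 1 to compound 2, (methyl in place of hydrogen on an oxygen on an aromatic ring), made a step of a number 5 percentage points lower from compound 1 to compound 2 (within the scatter). The cores of compound 1 and compound 3 differ by 4-methoxyphenyl in place of 2-nitrophenyl on a saturated chain carbon bound to an amide-type nitrogen in a ring, a step of a number 3.8 percentage points lower from compound 1 to compound 3 (within the scatter). Compound 4 `COc1ccc(CNC(=N)[C@@H]2CCC(=O)N2Cc2ccc(OC)cc2)cc1` is not yet measured; it differs from compound 3 by methyl in place of hydrogen on an oxygen on an aromatic ring, the same change as that from compound 1 to compound 2. Because that earlier step was a number 5 percentage points lower from compound 1 to compound 2 (within the scatter), a step of similar size is expected from compound 3 to compound 4, estimated as a number 3.6 percentage points lower from compound 3 to compound 4 (within the scatter). Compound 4 is therefore expected to give about 23% in this assay, most likely between 14% and 32%.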

Compound 4, a percentage reported as activity, at one concentration (the size of the read-out at that concentration, not a potency): 33.6%
For compound 4 the middle estimate is 10.6 percentage points below the measured one; measured number outside the range, above it.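

In this assay, hydroxy to methoxy on the 4-hydroxybenzyl group gave a number 7 percentage points higher from compound 3 to compound 4 (within the scatter), and this does not differ from the earlier reading of the same change: the same change on two cores in this assay, a number 5 percentage points lower (within the scatter) from compound 1 to compound 2 and a number 7 percentage points higher (within the scatter) from compound 3 to compound 4, 12 percentage points apart, within the scatter of two such steps. The replacement of 2-nitrophenyl by 4-methoxyphenyl gave a number 8.2 percentage points higher from compound 2 to compound 4 (within the scatter), and the two readings of that change do not differ either: the same change on two cores in this assay, a number 3.8 percentage points lower (within the scatter) from compound 1 to compound 3 and a number 8.2 percentage points higher (within the scatter) from compound 2 to compound 4, 12 percentage points apart, within the scatter of two such steps. Each step lies within the scatter, so the opposite signs show no reversal between cores, and the data neither show that either change carries a real effect from one core to another nor show that its effect depends on the core.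

The compounds shown leave open whether an ethyl group or a longer chain on that oxygen, or an amine in place of the hydroxy, would give a step beyond the scatter. They also leave open how the read-out would respond at other concentrations.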